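The source may report more compounds than this note shows. Statements on the series, on what has been measured and on what is new or still open speak of the compounds shown alone.

Measured compounds:
- compound 1, `Cc1c(F)c(Oc2cccc(N)c2)nc(Oc2cccc(C(=N)N)c2)c1F`, > 5000 nM
- compound 2, `Cc1c(F)c(Oc2cccc(C(=N)N)c2)nc(Oc2cccc(C(=O)N3CCCC3)c2)c1F`, 2800 nM

In an assay on isolated protein for inhibition of serine protease 1 (Bos taurus) (on this read-out higher numbers stand for weaker inhibition and lower numbers for stronger inhibition), compound 1 gives only a limit of the assay, > 5000 nM, and no number, as the limit of > 5000 nM in this assay, at which 1 of the 2 values shown sits, shows. Compound 2, with a (pyrrolidin-1-yl)carbonyl in place of the amino on an aromatic carbon, gives 2800 nM; the step of an at least 1.7-fold lower number from compound 1 to compound 2 (0.25 log units; that floor lies within the scatter) is the only measured one and does not touch the change to compound 3.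

Compound 3, `Cc1ccc(N(C)C)cc1Oc1nc(Oc2cccc(C(=N)N)c2)c(F)c(C)c1F`, differs from compound 1 as follows: 5-(dimethylamino)-2-methylphenyl in place of 3-aminophenyl on an oxygen on an aromatic ring. Among the measured compounds shown here, no measured step covers this change, so the expectation rests on the limit of compound 1 alone. Compound 3 is therefore expected to remain weak, with a step of about a number no higher from compound 1 to compound 3 (the limit leaves the size open) in this assay, and an estimated value of 5000 nM, likely between 1500 nM and 15000 nM, with a fair chance that again only a limit is reported.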

Compound 3, inhibition constant: > 5000 nM
Compound 3 was reported as a limit; the forecaster's own chance of this, stated with the estimate: 55%; the middle value lies on the limit itself.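

In this assay, among the compounds shown here, compound 3 gives only a limit, > 5000 nM, and compound 1 also gives only a limit, so no step between them can be read. The compounds shown leave open whether 5-(dimethylamino)-2-methylphenyl in place of 3-aminophenyl changes inhibition at all.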